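The source may report more compounds than this note shows. Statements on the series, on what has been measured and on what is new or still open speak of the compounds shown alone.

Measured so far in a functional assay on EOL1 cells (Homo sapiens) for inhibition, read by fluorescence, with a stated time of 72 h (on this read-out higher numbers stand for weaker inhibition of growth and lower numbers for stronger inhibition of growth), on the shared core:

compound 1 `CC(C)CCn1cnc2c(Nc3ccc(Cl)cc3)nc(N[C@H]3CC[C@H](N)CC3)nc21` gives 90 nM
compound 2 `CCCCCCn1cnc2c(Nc3ccc(Cl)cc3)nc(N[C@H]3CC[C@H](N)CC3)nc21` gives 440 nM
compound 3 `CCCCn1cnc2c(Nc3ccc(Cl)cc3)nc(N[C@H]3CC[C@H](N)CC3)nc21` gives 50 nM

Compound 1 and compound 3 lie within the scatter of each other, and compound 2 stands apart with the highest number.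

Next is compound 4 `CC(C)CCn1cnc2c(Nc3ccc(O)cc3)nc(N[C@H]3CC[C@H](N)CC3)nc21`, which keeps the chain and core of compound 1 and carries this change: hydroxy in place of chloro on an aromatic carbon. In words, hydroxy in place of chloro on an aromatic carbon, para to a large group, so 4-chlorophenyl becomes 4-hydroxyphenyl.

For the measured compounds named here, no measured step touches this position. All three lie on the chain at the aromatic nitrogen. Two are modest (a 4.9-fold higher number from compound 1 to compound 2 (0.69 log units; beyond the scatter) and an 8.8-fold lower number from compound 2 to compound 3 (0.94 log units; beyond the scatter)) and one stays within the scatter (a 1.8-fold lower number from compound 1 to compound 3 (0.26 log units; within the scatter)). They give no direction for the new change and serve only as a rough guide to size, showing what one local change has done on this core. A modest move towards a higher number in this assay is assumed, held loosely, with no change beyond the scatter also possible.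

The expected step is a 2.2-fold higher number from compound 1 to compound 4 (0.35 log units; beyond the scatter) and remains an estimate.

For compound 4 the estimated value is 200 nM, with an expected range from 50 nM to 800 nM.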

Compound 4, concentration for 50% growth inhibition: 30 nM
Estimate against measurement, compound 4: 6.7-fold (0.82 log units) above; the whole stated range lies above it.
By their numbers in this assay, from the lowest: compounds 4, 3 and 1 (each within the scatter of the next, the first and the last beyond it); then compound 2.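

For the compounds shown here, the earlier compounds varied only the chain at the aromatic nitrogen, so this is the first reading at the aromatic carbon para to a large group. In this assay, hydroxy in place of chloro gives a 3.0-fold lower number from compound 1 to compound 4 (0.48 log units; beyond the scatter), so on this chain the chloro group is not needed for growth inhibition, and the 4-hydroxyphenyl group, with its hydrogen-bond donor and acceptor, goes with the lower number. The series shows only the size and direction of this step, and no available data bear on its cause.

Among the compounds shown, the change appears only on the chain of compound 1, so whether it carries over to the butyl chain of compound 3 or the hexyl chain of compound 2 remains open. Also open, on these data alone, is how other groups at this position, such as methoxy, fluoro, an amine or a carboxylic acid, would compare with hydroxy and chloro, and whether a methoxy group, which lacks the hydroxy hydrogen, would keep the lower number.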